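Amide substituent swap on the carbamoyl nitrogen

The source may hold more compounds than are shown below. What is called first, only, known or untested is meant among the compounds shown, and "the series" means these compounds.

Three compounds of the series have measured numbers. Compound 1 `CN1CCC(NS(=O)(=O)c2ccccc2Nc2cc(-c3ccc4ccn(C)c4c3)c3nccnc3c2)C1` gives 3160 nM in an assay on lysate for inhibition of 6-phosphofructo-2-kinase/fructose-2,6-bisphosphatase 3 (Homo sapiens), with stated times of 0.5 min and 45 min; a higher number here means a weaker inhibitor, a lower number a stronger inhibitor. Compound 2 `Cn1ccc2ccc(-c3cc(Nc4cnccc4C(=O)NC4CCNC(=O)C4)cc4nccnc34)cc21` gives 56500 nM in this assay, and compound 3 `CN1CCC(NC(=O)c2ccncc2Nc2cc(-c3ccc4ccn(C)c4c3)c3nccnc3c2)CC1=O` gives 48800 nM in this assay. Compound 3 therefore stands second highest of the three numbers, with compound 2 nearest and compound 1 furthest. Going by the values given here, the only single-point step measured so far is a 1.2-fold lower number from compound 2 to compound 3 (0.06 log units; within the scatter). Compound 1 differs from compound 3 in more than one place, so the gap between their two numbers cannot be assigned to any single change.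

Compound 4 `CC(=O)N1CC(CNC(=O)c2ccncc2Nc2cc(-c3ccc4ccn(C)c4c3)c3nccnc3c2)C1` is not yet measured. It differs from compound 3 in one place: (1-acetylazetidin-3-yl)methyl in place of 1-methyl-2-oxopiperidin-4-yl on an amide-type nitrogen. Among the compounds with values here, no measured step varies the ring of the amide substituent in this way; the one step that touches the same region, from compound 2 to compound 3, stayed within the scatter, and that step is a different change. The data therefore give no direction for this exchange, and a step of no more than the scatter is expected, written as a 1.2-fold lower number from compound 3 to compound 4 (0.09 log units; within the scatter). For compound 4 the estimated value in this assay is 40000 nM, with an expected range of 10000 nM to 160000 nM.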

Compound 4, half-maximal inhibitory concentration: > 100000 nM
Compound 4: no number, only a limit; the forecaster's own chance of this, stated with the estimate: 10%; middle value at least 2.5-fold (0.39 log units) away from the limit.
By their numbers in this assay, from the lowest: compound 1; then compounds 3 and 2 (each within the scatter of the next). At a limit, above all of these: compound 4.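

Going by these compounds alone, replacing 1-methyl-2-oxopiperidin-4-yl with (1-acetylazetidin-3-yl)methyl on the amide-type nitrogen leaves the heavy-atom count and the counts of hydrogen-bond donors and acceptors unchanged, yet it gives an at least 2.0-fold higher number from compound 3 to compound 4 (0.31 log units; beyond the scatter), the only step at this position printed as beyond the scatter. The position therefore does respond to the amide substituent, which the earlier step between the two oxopiperidine compounds did not show. The comparison with the unmethylated oxopiperidine gives an at least 1.7-fold higher number from compound 2 to compound 4 (0.24 log units; that floor lies within the scatter), so that floor alone does not separate the two compounds.

Compound 4 gives > 100000 nM in this assay, and this is a limit of the assay, not a number, so both new steps are floors and their full size is unknown: the limit of > 100000 nM in this assay, at which 1 of the 4 values shown sits.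

The exchange alters the ring size, the methylene link and the placing of the carbonyl all at once, and the compounds shown do not assign the step to any one of these. A 1-acetylazetidin-3-yl group set directly on the amide-type nitrogen, or a (1-acetylpiperidin-4-yl)methyl group, would begin to separate these changes.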